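A Methyl on the Benzyl Ring of Compound 2

This account rests on a few compounds, and the source may have more. Where it says the series, first, only, none or still open, it means among the compounds named here.

Two compounds share one core. Compound 1 `CN1CCN(CCCOc2c(OCc3ccccc3)cc(O)c3c(=O)cc(-c4ccccc4)oc23)CC1` gives 3110 nM in a functional assay on HepG2 cells (Homo sapiens) for cytotoxicity, read by MTT assay, with a stated time of 72 h; on this read-out lower numbers stand for stronger inhibition and higher numbers for weaker inhibition. Compound 2 `CN1CCN(CCCCOc2c(OCc3ccccc3)cc(O)c3c(=O)cc(-c4ccccc4)oc23)CC1`, which differs from it only in the chain, gives 1500 nM in this assay, and the step of a 2.1-fold lower number from compound 1 to compound 2 (0.32 log units; beyond the scatter) is modest but beyond the scatter. Within the data shown here, compound 2 therefore holds the lowest of the two numbers so far.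

Compound 3 `Cc1ccc(COc2cc(O)c3c(=O)cc(-c4ccccc4)oc3c2OCCCCN2CCN(C)CC2)cc1` is compound 2 with methyl in place of hydrogen on an aromatic carbon. Among the measured compounds shown here, none of the measured steps touches this ring: the only step available concerns the chain between the two nitrogen-bearing ring and the ether oxygen, and it says nothing about a methyl on the benzyl group. With no comparison to lean on, no step beyond the scatter is expected in this assay from compound 2 to compound 3, in either direction.

Compound 3 is accordingly estimated at 1500 nM in this assay, with a range from 600 nM to 4000 nM, which corresponds to an expected step of no change at the digits printed from compound 2 to compound 3 (within the scatter).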

Compound 3, half-maximal inhibitory concentration: 5090 nM
The estimate for compound 3 lay 3.4-fold (0.53 log units) below the measured number; measured number above the stated range.
By their numbers in this assay, from the lowest: compound 2; then compounds 1 and 3 (each within the scatter of the next).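

In this assay, the benzyl group proves sensitive to a small change: 4-methylbenzyl in place of benzyl gives a 3.4-fold higher number from compound 2 to compound 3 (0.53 log units; beyond the scatter). Among these compounds, this is the first measured step on this ring, and it runs toward weaker inhibition, so that a single methyl, para to a large group, is enough to move the number beyond the scatter and compound 2 keeps the lowest number of the three. No measurement shown here explains this rise.

From the compounds shown here alone, whether a fluorine or a methoxy group at the same carbon would give a similar step remains open, as does the effect of a methyl elsewhere on this ring. Going by these compounds, it is also open whether the methyl would give a like step on the chain of compound 1 or on a longer chain.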